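Swapping a tolyl group for a chlorobenzoyl on a hydrazide

A few compounds are considered here, and "the series" means these few. Any claim that something is new, unique, unknown or untested is made for them only; others in the source may bear on it.

Measured so far in a functional assay on A549 cells (Homo sapiens) for antiproliferative activity, read by MTT assay, with a stated time of 24 h; on this read-out higher numbers stand for weaker inhibition and lower numbers for stronger inhibition:
- compound 1 `Cc1ccccc1NNC(=O)c1ccccc1NS(=O)(=O)c1cnc(O)nc1O`: > 20000 nM
- compound 2 `O=C(NNC(=O)c1cccc(Cl)c1)c1ccc(NS(=O)(=O)c2cnc(O)nc2O)cc1`: 2290 nM
- compound 3 `Cc1ccc(C(=O)NNC(=O)c2cccc(NS(=O)(=O)c3cnc(O)nc3O)c2)cc1`: > 20000 nM

Of the compounds shown here, three sharing one core have been tested in this assay. Compound 1 returns > 20000 nM, which is a limit of the assay and not a number. Compound 3 likewise returns > 20000 nM, again a limit. Among the measured compounds shown here, compound 2 gives 2290 nM, the only measured number in the set. Compound 1 therefore stands at the limit of > 20000 nM in this assay, at which 2 of the 3 values shown sit, together with compound 3, while compound 2 shows that a value inside the measurable range can be reached within this series.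

The untested compound 4 `O=C(NNC(=O)c1ccccc1NS(=O)(=O)c1cnc(O)nc1O)c1cccc(Cl)c1` differs from compound 1 in one place: (3-chlorophenyl)carbonyl in place of 2-methylphenyl on an amine nitrogen. For the measured compounds named here, no step between two measured compounds covers this change, so its size is unknown. Because compound 1 sits at the limit of > 20000 nM in this assay, at which 2 of the 3 values shown sit, only a move toward stronger inhibition could be read as a number at all; a change in the other direction, or none, would again give a limit.

Compound 4 is expected to give 15000 nM, with a range from 3000 nM to 40000 nM. The estimated step of an at least 1.3-fold lower number from compound 1 to compound 4 (0.12 log units; that floor lies within the scatter) is modest, and it is roughly an even chance that this assay again reports only a limit for compound 4.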

Compound 4, half-maximal inhibitory concentration: 1260 nM
Compound 4: the middle estimate sits 12-fold (1.08 log units) above what was measured, outside the stated range (below it).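

In this assay, the amine nitrogen at the end of the hydrazide in compound 1 proves to be a place where a change can bring measurable activity: (3-chlorophenyl)carbonyl in place of 2-methylphenyl gives an at least 15-fold lower number from compound 1 to compound 4 (1.20 log units; beyond the scatter). The swap turns a (2-methylphenyl)amino end into a ((3-chlorophenyl)carbonyl)amino end, so a carbonyl and a chlorine enter together, and a different ring comes with them; this single step cannot divide the gain among those parts. The step gives only a minimum and not a true size, because the value of compound 1 is a limit of the assay and not a number: the limit of > 20000 nM in this assay, at which 2 of the 4 values shown sit.

Going by these compounds, what remains open is which part of the new group goes with the stronger inhibition, since a plain benzoyl group without chlorine, or a small acetyl group without any ring, would pull the carbonyl and the chlorinated ring apart. On these data alone, it is also open whether the chlorine matters at all, which a fluorine or a methoxy group on the same ring could begin to test.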